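Swapping methoxy for fluoro on the piperidine-linked aryl

The source may hold more compounds than are shown below. What is called first, only, known or untested is meant among the compounds shown, and "the series" means these compounds.

Compound 1 `COc1ccccc1C1CCN(CC(=O)Nc2cccc(C)c2)CC1`: 420 nM
Compound 2 `Cc1ccc(C(=O)NCN2CCC(c3cccc[n+]3[O-])CC2)cc1C`: 38 nM

For the measured compounds named here, in a functional assay on HEK293 cells for agonist activity at D(4) dopamine receptor (Homo sapiens), read by FLIPR (on this read-out higher numbers stand for an effect only at larger amounts of compound and lower numbers for an effect already at smaller amounts), compound 1 gives 420 nM, the higher of the two numbers measured so far. Compound 2 gives 38 nM, a lower number, and the gap between the two lies beyond the usual scatter. Compound 3 `Cc1cccc(NC(=O)CN2CCC(c3ccccc3F)CC2)c1` has not yet been measured. It differs from compound 1 by fluoro in place of methoxy on an aromatic carbon. Going by the values given here, no measured pair shows this change, so only a modest shift is expected. Compound 3 is estimated at 500 nM, in the range 150 nM to 1600 nM. On that estimate a 1.2-fold higher number from compound 1 to compound 3 (0.08 log units; within the scatter) is expected to stay within the scatter.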

Compound 3, half-maximal effective concentration: 1 nM
Compound 3: middle estimate off by 500-fold (2.70 log units), on the high side; measured number below the stated range.
By their numbers in this assay, from the lowest: compound 3; then compound 2; then compound 1.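

In this assay, fluoro in place of methoxy on an aromatic carbon, ortho to a large group, gives a 420-fold lower number from compound 1 to compound 3 (2.62 log units; beyond the scatter). For the compounds shown here, this is the first sign that this place on the core of compound 1 responds strongly to what it carries, and that a change of one group here can move the number by a large step. Nothing available accounts for the size of this step. The compounds shown leave open whether chloro, an amine or plain hydrogen at this place would give a similarly low number. They also leave open whether fluoro would do the same on another aromatic carbon.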